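The source may hold more compounds than are shown below. What is called first, only, known or untested is meant among the compounds shown, and "the series" means these compounds.

Measured compounds:
Compound 1, `C[C@H](Nc1ncnc2[nH]cnc12)c1nn(-c2ccncc2)c2cc(F)ccc12`: in a functional assay on HepG2 cells (Homo sapiens) for inhibition, read by sulforhodamine B assay, with a stated time of 72 h (on this read-out lower numbers stand for stronger inhibition and higher numbers for weaker inhibition), compound 1 gives 23100 nM.
Compound 2, `CC[C@H](Nc1ncnc2[nH]cnc12)c1nn(-c2cccnc2)c2cc(F)ccc12`: in this assay compound 2 gives 33900 nM.
Compound 3, `Cc1ccc2c(c1)c([C@H](C)Nc1ncnc3[nH]cnc13)nn2-c1cccnc1`: in this assay compound 3 returns no number but a limit of the assay, > 40000 nM.

All three measured compounds share one core and differ in the group on the aromatic nitrogen and in the substituent on the fused ring. Compound 1 and compound 2 lie within the usual scatter of each other, so neither can be placed above the other. Compound 3 stands apart only in that its value is a limit, (the limit of > 40000 nM in this assay, at which 1 of the 3 values shown sits), and it gives no number to compare.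

Compound 4, `C[C@H](Nc1ncnc2[nH]cnc12)c1nn(-c2cc(F)cc(F)c2)c2cc(F)ccc12`, has not been measured in this assay. It differs from compound 1 in one place: 3,5-difluorophenyl in place of pyridin-4-yl on an aromatic nitrogen. Within the data shown here, no pair of measured compounds isolates this change, so no measured step can be carried over. The whole series sits weak, and a single swap of the group on the aromatic nitrogen is expected to move the number modestly, with the direction uncertain. The step of a 1.3-fold lower number from compound 1 to compound 4 (0.11 log units; within the scatter) is therefore expected to stay close to the scatter. For compound 4 the estimate is 18000 nM, between 5000 nM and 40000 nM.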

Compound 4, half-maximal inhibitory concentration: 22100 nM
Estimate against measurement, compound 4: 1.2-fold (0.09 log units) below; the measured number falls inside the stated range.
By their numbers in this assay, from the lowest: compounds 4, 1 and 2 (each within the scatter of the next). At a limit, above all of these: compound 3.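

Among these compounds, this pair is the first to isolate the group on the aromatic nitrogen, and in this assay it gives a 1.0-fold lower number from compound 1 to compound 4 (0.02 log units; within the scatter). Pyridin-4-yl carries a ring nitrogen and a hydrogen-bond acceptor, and 3,5-difluorophenyl has a carbon-only ring with fluorine and no acceptor, yet compound 1 and compound 4 stay within the scatter of each other. For this one pair, then, the ring nitrogen of the pyridin-4-yl group is not required for the weak inhibition seen, and nothing shown gives a reason for the flat result.

The compounds shown leave open whether any group at this position can separate from the scatter at all, for instance a morpholine ring, a carboxylic acid or an aminoalkyl chain in place of the aromatic ring. They also leave open what the fluorine on the fused ring contributes, since no pair shown differs from compound 1 in that place alone.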